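The source may hold more compounds than are shown below. What is called first, only, known or untested is meant among the compounds shown, and "the series" means these compounds.

In a functional assay on SK-MEL-2 cells (Homo sapiens) for inhibition (on this read-out lower numbers stand for stronger inhibition of growth and higher numbers for weaker inhibition of growth), compound 1 (`COc1cc(/C=C/C(=O)c2cccc(-n3cc(-c4ccc(Cl)cc4)[nH]c3=O)c2)cc(OC)c1OC`) gives 3440 nM. Compound 2 (`COc1cc(/C=C/C(=O)c2cccc(-n3cc(-c4ccccc4)[nH]c3=O)c2)ccc1O`) gives 3650 nM and compound 3 (`O=C(/C=C/c1cccc(O)c1)c1cccc(-n2cc(-c3ccc(Cl)cc3)[nH]c2=O)c1`) gives 2070 nM, so compound 1 lies within the scatter of both. Compound 4 (`COc1ccc(-c2cn(-c3cccc(C(=O)/C=C/c4cc(OC)c(OC)c(OC)c4)c3)c(=O)[nH]2)cc1`) keeps the core of compound 1 and changes one place, 4-chlorophenyl to 4-methoxyphenyl: methoxy in place of chloro on an aromatic carbon, para to a large group (methoxy in place of chloro on an aromatic carbon). No measured pair sizes a change at this place. A step within the scatter is expected in this assay, with no favoured direction, given compound 1 at 3440 nM and the narrow spread of the three values. Estimated step: a 1.1-fold lower number from compound 1 to compound 4 (0.03 log units; within the scatter). For compound 4 the estimated value is 3200 nM, with an expected range of 1500 nM to 7000 nM.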

Compound 4, concentration for 50% growth inhibition: 2630 nM
For compound 4 the middle estimate is 1.2-fold (0.09 log units) above the measured one; the measured number falls inside the stated range.
By their numbers in this assay, from the lowest: compounds 3, 4, 1 and 2 (each within the scatter of the next).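

For the compounds shown here, at the 4-chlorophenyl place, the first sized step in this assay is a 1.3-fold lower number from compound 1 to compound 4 (0.12 log units; within the scatter), so this place accepts methoxy in place of chloro on an aromatic carbon, with its added hydrogen-bond acceptor, without a step beyond the scatter. No measured property bears on this result. Going by these compounds, whether an amine or a carboxylic acid on this aromatic carbon would move the number beyond the scatter stays open. So does whether the same change would give a similar step with the other substituents seen in compound 3.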